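Swapping the aryl group on the amine nitrogen of compound 2

A few compounds are considered here, and "the series" means these few. Any claim that something is new, unique, unknown or untested is made for them only; others in the source may bear on it.

Measured compounds in a functional assay on MCF7 cells (Homo sapiens) for inhibition, read by sulforhodamine B assay; on this read-out higher numbers stand for weaker inhibition and lower numbers for stronger inhibition:
- compound 1, `Cc1ccc(NC2=CC(=O)c3nc4n(c3C2=O)[C@H]2OC[C@@H](O)[C@H]2OC4)cc1C`: 2080 nM
- compound 2, `COc1ccc(NC2=CC(=O)c3c(nc4n3[C@H]3OC[C@@H](O)[C@H]3OC4)C2=O)cc1`: 4470 nM
- compound 3, `O=C1C=C(NCc2ccccc2)C(=O)c2c1nc1n2[C@H]2OC[C@@H](O)[C@H]2OC1`: a limit, > 8000 nM

Of the two compounds with a definite number, compound 2 shows the higher one, and compound 1 sits a step below it. The value for compound 3 is a limit of this assay, not a number, and it marks (the limit of > 8000 nM in this assay, at which 1 of the 3 values shown sits).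

For the measured compounds named here, the only single-point step among the measured compounds is an at least 3.8-fold higher number from compound 1 to compound 3 (0.58 log units; beyond the scatter), where an aromatic ring directly on the amine nitrogen gave way to a benzyl group; that change moved the value into the limit. The step to compound 4, `O=C1C(Nc2ccccc2F)=CC(=O)c2c1nc1n2[C@H]2OC[C@@H](O)[C@H]2OC1`, is different in kind: 2-fluorophenyl in place of 4-methoxyphenyl on an amine nitrogen. Here one aromatic ring on the amine nitrogen is exchanged for another, and no measured step covers such a swap. The step from compound 1 to compound 3 therefore says little about it, and the expected outcome is a change no larger than the scatter, perhaps a slight one in either direction.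

On that basis, compound 4 is expected at 4000 nM, within 1500 nM to 12000 nM, which amounts to an expected step of a 1.1-fold lower number from compound 2 to compound 4 (0.05 log units; within the scatter).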

Compound 4, half-maximal inhibitory concentration: > 4000 nM
Compound 4 gave a limit, no number; the forecaster's own chance of this, stated with the estimate: 20%; the middle value lies on the limit itself.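

The step from compound 2 to compound 4 cannot be read, because compound 4 gave a limit of the assay and not a number: the limit of > 4000 nM in this assay, at which 1 of the 4 values shown sits. The compounds shown leave open how far exchanging 4-methoxyphenyl for 2-fluorophenyl on the amine nitrogen changes the value, and whether it changes at all.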